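Swapping the sulfur substituent on a purine nucleoside inhibitor

A few compounds are considered here, and "the series" means these few. Any claim that something is new, unique, unknown or untested is made for them only; others in the source may bear on it.

Compound 1 `O=[N+]([O-])c1cccc2c1CCN(c1ncnc3c1nc1n3[C@@H]3O[C@H](CO1)[C@@H](O)[C@H]3O)C2`: 7410000 nM
Compound 2 `OC[C@H]1O[C@@H](n2cnc3c(SC4CCCCC4)ncnc32)[C@H](O)[C@@H]1O`: 6310 nM
Compound 3 `CC(C)Sc1nc(N)nc2c1ncn2[C@@H]1O[C@H](CO)[C@@H](O)[C@H]1O`: 191000 nM

In an assay on isolated protein for binding affinity to Equilibrative nucleoside transporter 1 (Homo sapiens) (a lower number here means a stronger inhibitor, a higher number a weaker inhibitor), compound 2 gives the lowest number of the three. Compound 3 sits clearly above it and compound 1 furthest away, both gaps beyond the scatter, so compound 2 is the strongest inhibitor of this set. Compound 4 `OC[C@H]1O[C@@H](n2cnc3c(CSc4ccc(F)cc4)ncnc32)[C@H](O)[C@@H]1O` differs from compound 2 in one place: ((4-fluorophenyl)sulfanyl)methyl in place of cyclohexylsulfanyl on an aromatic carbon. Within the data shown here, no measured pair covers such an exchange, so the expectation rests on compound 2 alone. The step is expected to be a 1.4-fold higher number from compound 2 to compound 4 (0.15 log units; within the scatter), small and, if anything, toward a weaker inhibitor. Compound 4 is therefore estimated at 9000 nM, with a range from 2000 nM to 40000 nM.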

Compound 4, half-maximal inhibitory concentration: 158 nM
For compound 4 the middle estimate is 57-fold (1.76 log units) above the measured one, and the stated range ends above it.
By their numbers in this assay, from the lowest: compound 4; then compound 2; then compound 3; then compound 1.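

In this assay, the group on this aromatic carbon has a large influence: ((4-fluorophenyl)sulfanyl)methyl in place of cyclohexylsulfanyl gives a 40-fold lower number from compound 2 to compound 4 (1.60 log units; beyond the scatter) in a single exchange. That exchange alters the ring and its link to the core together, so this pair cannot assign the step to either. Nothing available explains its size. As far as these compounds go, it remains open whether the fluorine, the aromatic ring or the extra carbon carries the step. A plain phenyl ring or a chlorine on that ring could separate these contributions.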